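Methyl on the alkyne terminus of a propargylamine indole

This account rests on a few compounds, and the source may have more. Where it says the series, first, only, none or still open, it means among the compounds named here.

Measured compounds:
compound 1 `CC#CCN(C)Cc1cc2cc(O)ccc2n1C`, 5.75 nM
compound 2 `CC#CCN(C)Cc1cc2cc(OC)ccc2n1C`, 1.41 nM
compound 3 `C#CCN(C)Cc1cc2ccccc2n1C`, 0.302 nM

In an assay on isolated protein for inhibition of Amine oxidase [flavin-containing] A (Rattus norvegicus) (a lower number here means a stronger inhibitor, a higher number a weaker inhibitor), compound 3 gives 0.302 nM, the lowest number of the three; compound 2 sits next, with 1.41 nM, and compound 1 furthest, with 5.75 nM. Within the data shown here, the only step between measured neighbours, a 4.1-fold lower number from compound 1 to compound 2 (0.61 log units; beyond the scatter), concerns the oxygen substituent on the aromatic ring and does not touch the alkyne.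

Compound 4 `CC#CCN(C)Cc1cc2ccccc2n1C` differs from compound 3 by methyl in place of hydrogen on a triple-bonded carbon, so that the chain becomes but-2-yn-1-yl. Among the measured compounds shown here, no measured pair isolates this change. Compounds 1 and 2 carry the same but-2-yn-1-yl chain and both give higher numbers than compound 3 in this assay, but each also differs from compound 3 on the aromatic ring, so their values only hint that the longer chain may not help. Compound 4 is therefore expected to give a somewhat higher number than compound 3, a step of a 3.3-fold higher number from compound 3 to compound 4 (0.52 log units; beyond the scatter). The estimate for compound 4 is 1 nM, within 0.3 nM to 4 nM.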

Compound 4, inhibition constant: 4.27 nM
Compound 4: middle estimate off by 4.3-fold (0.63 log units), on the low side; measured number above the stated range.
By their numbers in this assay, from the lowest: compound 3; then compound 2; then compounds 4 and 1 (each within the scatter of the next).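

In this assay the methyl on the triple-bonded carbon can now be read alone, and the change from propargyl to but-2-yn-1-yl is large: a 14-fold higher number from compound 3 to compound 4 (1.15 log units; beyond the scatter) on the otherwise unchanged core. With the but-2-yn-1-yl chain held constant, the aromatic substituent can also be read, giving a 3.0-fold higher number from compound 2 to compound 4 (0.48 log units; beyond the scatter) for hydrogen in place of methoxy, whereas hydrogen in place of hydroxy gives a 1.3-fold lower number from compound 1 to compound 4 (0.13 log units; within the scatter) and so separates neither compound from the other. Nothing shown here explains the size of the alkyne step.

The compounds shown leave open how an ethyl group or a phenyl ring on the alkyne terminus would read. From the compounds shown here alone, it also remains open whether methoxy or hydroxy on the aromatic ring would give similar steps with the propargyl chain.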